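From acetamido to ethoxy on the shared core

This account rests on a few compounds, and the source may have more. Where it says the series, first, only, none or still open, it means among the compounds named here.

Compound 3 `CC(=O)Nc1cc2nc(-c3ccccc3)nn(-c3ccccc3)c-2cc1=O` gives > 5000 nM in an ADME assay on GM00637 cells (Homo sapiens) for cytotoxicity, read by MTT assay, with a stated time of 72 h (a lower number here means a stronger inhibitor, a higher number a weaker inhibitor), and this is a limit, not a number. In this assay, compound 1 `Nc1cc2nc(-c3ccccc3)nn(-c3ccccc3)c-2cc1=O` gives 2040 nM and compound 2 `CCN(CC)c1cc2nc(-c3ccccc3)nn(-c3ccccc3)c-2cc1=O` gives 2730 nM, the measured step being a 1.3-fold higher number from compound 1 to compound 2 (0.13 log units; within the scatter).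

Compound 4 `CCOc1cc2nc(-c3ccccc3)nn(-c3ccccc3)c-2cc1=O` carries ethoxy in place of acetamido on an aromatic carbon. Within the data shown here, two measured steps bear on this change, an at least 2.4-fold higher number from compound 1 to compound 3 (0.38 log units; beyond the scatter) and an at least 1.8-fold higher number from compound 2 to compound 3 (0.26 log units; that floor lies within the scatter). Both reach the limit and set only a floor on their size. A modest move to a lower number is expected, giving an estimated at least 1.7-fold lower number from compound 3 to compound 4 (0.25 log units; that floor lies within the scatter). The estimate for compound 4 is 2800 nM, with an expected range of 1300 nM to 5000 nM.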

Compound 4, half-maximal inhibitory concentration: > 5000 nM
Compound 4: only a limit was reported; the forecaster's own chance of this, stated with the estimate: 20%; at least 1.7-fold (0.25 log units) between middle value and limit.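

In this assay, compound 4 reaches the same limit as compound 3, so the step between them cannot be read: the limit of > 5000 nM in this assay, at which 2 of the 4 values shown sit.

Ethoxy still separates from amino, with an at least 2.4-fold higher number from compound 1 to compound 4 (0.38 log units; beyond the scatter), while the floor against diethylamino is smaller, with an at least 1.8-fold higher number from compound 2 to compound 4 (0.26 log units; that floor lies within the scatter). The limit is thus reached both by acetamido, which has a hydrogen-bond donor, and by ethoxy, which has none.

On these data alone, the order of compound 3 and compound 4 stays open. Also open, as far as these compounds go, is whether a longer alkoxy chain or a carboxylic acid on this aromatic carbon would give a readable number.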